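From Carboxylic Acid to Pyrrolidine Amide on One Core

A few compounds are considered here, and "the series" means these few. Any claim that something is new, unique, unknown or untested is made for them only; others in the source may bear on it.

Compound 1 `CC(C)=CCC[C@]1(C)/C=C/[C@@H](OC(=O)C=C(C)C)[C@](C)(O)/C=C/C(=O)/C(C(=O)O)=C\C1` stands in a functional assay on SW480 cells (Homo sapiens) for antiproliferative activity, read by MTT assay, with a stated time of 48 h (on this read-out higher numbers stand for weaker inhibition and lower numbers for stronger inhibition), only at a limit, giving > 10000 nM (the limit of > 10000 nM in this assay, at which 1 of the 2 values shown sits). Compound 2 `CC(C)=CCC[C@]1(C)/C=C/[C@@H](OC(=O)C=C(C)C)[C@](C)(O)/C=C/[C@H](O)/C(CO)=C\C1` likewise reaches only a limit in this assay, giving > 40000 nM. For the measured compounds named here, no step between measured compounds is available, so no measured change guides the next move. Compound 3 `CC(C)=CCC[C@]1(C)/C=C/[C@@H](OC(=O)C=C(C)C)[C@](C)(O)/C=C/C(=O)/C(C(=O)N2CCCC2)=C\C1` differs from compound 1 by pyrrolidin-1-yl in place of hydroxy on a carbonyl carbon. A modest shift toward stronger inhibition is expected, an at least 1.2-fold lower number from compound 1 to compound 3 (0.09 log units; that floor lies within the scatter), though it may not exceed the scatter. Compound 3 is therefore estimated at 8000 nM, within a range from 2000 nM to 30000 nM.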

Compound 3, half-maximal inhibitory concentration: 15100 nM
Compound 3: middle estimate off by 1.9-fold (0.28 log units), on the low side; the range from low to high includes it.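

The step from compound 1 to compound 3 cannot be read, since compound 1 stands only at a limit: the limit of > 10000 nM in this assay, at which 1 of the 3 values shown sits.

From the compounds shown here alone, whether (pyrrolidin-1-yl)carbonyl in place of carboxy gives stronger or weaker inhibition on the shared core stays open.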